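This account rests on a few compounds, and the source may have more. Where it says the series, first, only, none or still open, it means among the compounds named here.

Measured in a functional assay on A549 cells (Homo sapiens) for cytotoxicity, read by MTT assay, with a stated time of 72 h; on this read-out higher numbers stand for weaker inhibition and lower numbers for stronger inhibition:
- compound 1 `COc1ccc(/C=C2\CCC/C(=C\c3ccc(Br)cc3)C2=O)cc1OC`: 16000 nM
- compound 2 `COc1ccc(/C=C2\CCC/C(=C\c3ccc(OC)c(OC)c3)C2=O)cc1`: > 20000 nM (a limit)
- compound 3 `COc1ccc(/C=C2\CCC/C(=C\c3cccc(Cl)c3Cl)C2=O)cc1OC`: > 20000 nM (a limit)

Compound 3 gives only a limit, > 20000 nM. The next compound is compound 4 `COc1ccc(/C=C2\CCC/C(=C\c3ccc(O)c(O)c3)C2=O)cc1OC`, with 3,4-dihydroxyphenyl in place of 2,3-dichlorophenyl on a double-bonded chain carbon bound to a double-bonded ring carbon.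

Among the compounds with values here, two measured steps touch this place: an at least 1.2-fold higher number from compound 1 to compound 3 (0.09 log units; that floor lies within the scatter), and a step that the two limits leave unreadable from compound 2 to compound 3. Within the data shown here, no measured compound carries 3,4-dihydroxyphenyl, so neither step sizes this change. Compound 1 is the only numeric anchor at 16000 nM, so a modest move towards lower numbers is expected in this assay. Another limit remains possible. The expected step is an at least 1.6-fold lower number from compound 3 to compound 4 (0.22 log units; that floor lies within the scatter). The estimate for compound 4 is 12000 nM, with an expected range of 4000 nM to 24000 nM.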

Compound 4, half-maximal inhibitory concentration: > 20000 nM
Compound 4: only a limit was reported; the forecaster's own chance of this, stated with the estimate: 35%; middle value at least 1.6-fold (0.22 log units) away from the limit.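

In this assay compound 4 gives only a limit, > 20000 nM, so the hydrogen-bond donors of 3,4-dihydroxyphenyl, absent from 2,3-dichlorophenyl, yield no readable value on this double-bonded chain carbon. Within the data shown here, the only readable new step is an at least 1.2-fold higher number from compound 1 to compound 4 (0.09 log units; that floor lies within the scatter); the other new steps cannot be read. The series now clusters at a single limit: the limit of > 20000 nM in this assay, at which 3 of the 4 values shown sit.

As far as these compounds go, how far compound 4 lies past that limit stays open. Also open, from the compounds shown here alone, is whether an amine or a carboxylic acid at this place would give a numeric value in this assay.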